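Methylphenyl for Fluorophenyl: Cytotoxicity Expected Unchanged

The source may report more compounds than this note shows. Statements on the series, on what has been measured and on what is new or still open speak of the compounds shown alone.

The study covers a small set of related compounds. Compound 1 `Cn1c(-c2ccccc2F)cnc1NC(=O)c1ccc(F)cc1` is one of them. In a toxicity assay on THP-1 cells (Homo sapiens) for inhibition (on this read-out higher numbers stand for lower toxicity in this test and lower numbers for higher toxicity in this test), compound 1 gives > 100000 nM, which is a limit of the assay rather than a number. Compound 2 `COc1ccc(-c2cnc(NC(=O)C3CCCCC3)n2C)cc1` is the other measured member. In this assay compound 2 gives > 100000 nM, again a limit of the assay. The evidence is the limit of > 100000 nM in this assay, at which 2 of the 2 values shown sit, so compound 1 stands where the other measured compound stands, at the edge of what this test can report. Within the data shown here, no step between two measured compounds is available. Compound 3 `Cc1ccc(-c2cnc(NC(=O)c3ccc(F)cc3)n2C)cc1` is not yet measured; it differs from compound 1 by 4-methylphenyl in place of 2-fluorophenyl on an aromatic carbon. With both measured values at the limit, the step from compound 1 to compound 3 is expected to be none beyond the scatter, that is a number no higher from compound 1 to compound 3 (the limit leaves the size open). Compound 3 is therefore estimated at 100000 nM, within 50000 nM to 300000 nM, with a limit the likeliest report.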

Compound 3, half-maximal cytotoxic concentration: 60000 nM
Beside the measured number, compound 3's estimate is 1.7-fold (0.22 log units) above it, within the range that was stated.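

Among these compounds, compound 3 is the first compound here to give a number rather than a limit in this assay, so this position on the shared core can carry a group for which the test reports a value. The change to 4-methylphenyl from 2-fluorophenyl gives an at least 1.6-fold lower number from compound 1 to compound 3 (0.22 log units; that floor lies within the scatter), so the data do not establish a real shift in toxicity, although the true gap may be larger. The reading for compound 1 leaves that size open, and most of the values still sit at the edge of the test: the limit of > 100000 nM in this assay, at which 2 of the 3 values shown sit.

The compounds shown leave open whether the swap of fluorine for methyl or the changed place of the group on the phenyl ring matters here. They also leave open how 4-fluorophenyl, 2-methylphenyl or a phenyl ring carrying an amine or a carboxylic acid would read at this position.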